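This account rests on a few compounds, and the source may have more. Where it says the series, first, only, none or still open, it means among the compounds named here.

Compounds measured in a functional assay on ECa-109 cells for inhibition, with ECa-109 cell line (Homo sapiens) as the target, read by MTT assay, with a stated time of 48 h (on this read-out higher numbers stand for weaker inhibition and lower numbers for stronger inhibition), so far:
compound 1 `COc1ccc(-c2coc3cc(OCCCSC(=S)N4CCN(Cc5ccccc5)CC4)ccc3c2=O)cc1` gives 25300 nM;
compound 2 `CCN1CCN(C(=S)SCCCOc2ccc3c(=O)c(-c4ccc(OC)cc4)coc3c2)CC1` gives 36900 nM;
compound 3 `COc1ccc(-c2coc3cc(OCCCSC(=S)N4CCN(C(=O)OC(C)(C)C)CC4)ccc3c2=O)cc1` gives 3540 nM.

Compound 2 holds the highest number of the three, though the step of a 1.5-fold higher number from compound 1 to compound 2 (0.16 log units; within the scatter) lies within the scatter, while a 10-fold lower number from compound 2 to compound 3 (1.02 log units; beyond the scatter) lies beyond it. Compound 4 `COc1ccc(-c2coc3cc(OCCCCBr)ccc3c2=O)cc1` differs from compound 2 by a group of 2 heavy atoms (1 carbon, 1 bromine; no ring) in place of a group of 11 heavy atoms (7 carbon, 2 nitrogen, 2 sulfur; one six-membered non-aromatic ring with 2 hetero atoms), on a saturated chain carbon, three bonds along the chain from an oxygen on an aromatic ring. Among the measured compounds shown here, the measured steps of a 7.1-fold lower number from compound 1 to compound 3 (0.85 log units; beyond the scatter) and a 10-fold lower number from compound 2 to compound 3 (1.02 log units; beyond the scatter) only alter the group on the amine nitrogen inside the part that leaves; no measured step removes that whole part, so they bear on this change only loosely and give no firm direction. Compound 4 is therefore expected to stay near compound 2, with the step of a 1.2-fold lower number from compound 2 to compound 4 (0.09 log units; within the scatter) estimated as not beyond the scatter. The estimate for compound 4 in this assay is 30000 nM, within 8000 nM to 120000 nM.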

Compound 4, half-maximal inhibitory concentration: 66300 nM
Estimate against measurement, compound 4: 2.2-fold (0.34 log units) below; the measured number falls inside the stated range.
By their numbers in this assay, from the lowest: compound 3; then compounds 1, 2 and 4 (each within the scatter of the next, the first and the last beyond it).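

In this assay, among the compounds shown here, the step of a 1.8-fold higher number from compound 2 to compound 4 (0.25 log units; within the scatter) is the first to remove the whole group carrying the six-membered ring from this saturated chain carbon, and it puts bromomethyl there. The number stays within the scatter, so on this read-out compound 2 cannot be told apart from compound 4 despite losing that entire group. Nothing available accounts for this outcome. Going by these compounds, what a hydroxyl or an amine would give in place of the bromomethyl stays open. So does the outcome with a longer chain between the aromatic oxygen and the end group.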